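Removing the chloro from compound 1: a step in the dark

This account rests on a few compounds, and the source may have more. Where it says the series, first, only, none or still open, it means among the compounds named here.

Compound 1 `O=c1c(C(=S)Nc2ccccc2)coc2cc(Cl)ccc12` was tested in a functional assay on COLO 205 cells (Homo sapiens) for inhibition, read by sulforhodamine B assay, with a stated time of 48 h; a higher number here means a weaker inhibitor, a lower number a stronger inhibitor. In this assay compound 1 gives only a limit, > 100000 nM, not a number. Its close relative compound 2 `O=c1c(C(=S)Nc2ccccc2)coc2cc(Cl)c(Cl)cc12` likewise returns only a limit in this assay, > 100000 nM. The step from chloro in place of hydrogen on an aromatic carbon, a step that the two limits leave unreadable from compound 1 to compound 2, therefore cannot be read in size, because both of its ends sit at the same boundary, (the limit of > 100000 nM in this assay, at which 2 of the 2 values shown sit). So compound 1 stands at a limit of the assay, with no number to place it above or below compound 2.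

The change now followed is the reverse kind of edit: compound 3 `O=c1c(C(=S)Nc2ccccc2)coc2ccccc12` carries hydrogen in place of chloro on an aromatic carbon, (hydrogen in place of chloro on an aromatic carbon). The only measured step of this family gives no readable size, so no direction can be drawn from it, and nothing in the shown numbers argues that losing the chloro will bring compound 3 within the range of the assay. Compound 3 is therefore expected to sit near the same boundary, with an estimated value of 150000 nM spanning 40000 nM to 600000 nM. The step from compound 1 to compound 3 is thus expected to be a step that the limit leaves unreadable from compound 1 to compound 3, most likely again reported only as a limit.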

Compound 3, half-maximal inhibitory concentration: 72600 nM
Compound 3: the middle estimate sits 2.1-fold (0.32 log units) above what was measured; measured number inside the range.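

Going by these compounds alone, with hydrogen in place of chloro on the aromatic carbon, compound 3 is the only one of the three compounds to return a number in this assay, and this gives the change a lower bound: an at least 1.3-fold lower number from compound 1 to compound 3 (0.13 log units; that floor lies within the scatter). That bound is a floor and not a size, so the result shows that this position can be left without chloro with no loss of a readable value, but it does not show that removing the chloro improves inhibition beyond the usual spread of repeat measurements. The measured value of compound 3 also stays at the weak end of the range, not far inside the boundary that holds the other two compounds: the limit of > 100000 nM in this assay, at which 2 of the 3 values shown sit.

From the compounds shown here alone, how far compound 1 truly lies from compound 3 stays open, since compound 1 gives only a limit and the real gap could be anywhere from negligible to large. Also open, going by these compounds, is whether a fluoro, a methoxy or an amine on this same aromatic carbon would bring the number down further than hydrogen does.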